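A few compounds are considered here, and "the series" means these few. Any claim that something is new, unique, unknown or untested is made for them only; others in the source may bear on it.

Three compounds with the same core differ only in the group on a saturated chain carbon bound to a sulfur. In a functional assay on SW-620 cells (Homo sapiens) for cytotoxicity, read by MTT assay, with stated times of 4 h and 72 h, tested at 5 uM (on this read-out lower numbers stand for stronger inhibition and higher numbers for weaker inhibition), compound 1 (`Cc1cc(Nc2ccc(C(=O)/C=C/c3ccc4ccccc4c3)cc2)n2nc(SCc3ccc(Cl)cc3)nc2n1`) gives 570 nM, compound 2 (`Cc1ccc(CSc2nc3nc(C)cc(Nc4ccc(C(=O)/C=C/c5ccc6ccccc6c5)cc4)n3n2)cc1`) gives 880 nM and compound 3 (`Cc1cc(Nc2ccc(C(=O)/C=C/c3ccc4ccccc4c3)cc2)n2nc(SCc3cccc([N+](=O)[O-])c3)nc2n1`) gives 790 nM. Compound 3 therefore stands within the scatter of both other compounds, as shown by a 1.1-fold lower number from compound 2 to compound 3 (0.05 log units; within the scatter) and by a 1.4-fold higher number from compound 1 to compound 3 (0.14 log units; within the scatter).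

The next compound is compound 4 (`Cc1cc(Nc2ccc(C(=O)/C=C/c3ccc4ccccc4c3)cc2)n2nc(SCc3ccccc3C(F)(F)F)nc2n1`), which carries 2-(trifluoromethyl)phenyl in place of 3-nitrophenyl on a saturated chain carbon bound to a sulfur. The measured steps that bear on this change are the exchanges at the same place. Besides the two already given, there is a 1.5-fold higher number from compound 1 to compound 2 (0.19 log units; within the scatter). None of the three goes beyond the scatter, although they span chloro, methyl and nitro variants. Going by the values given here, still, no measured compound carries a trifluoromethyl group, so the data offer no direct precedent for it and favour no direction. On that basis, no step beyond the scatter is expected, and the estimated step is a 1.1-fold lower number from compound 3 to compound 4 (0.03 log units; within the scatter). The estimate for compound 4 is 740 nM, with an expected range from 380 nM to 1400 nM.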

Compound 4, half-maximal inhibitory concentration: 1240 nM
The estimate for compound 4 lay 1.7-fold (0.22 log units) below the measured number; the measured number falls inside the stated range.
By their numbers in this assay, from the lowest: compounds 1, 3, 2 and 4 (each within the scatter of the next, the first and the last beyond it).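

In this assay, going by these compounds alone, the exchange on a saturated chain carbon bound to a sulfur now gives its first step beyond the scatter (a 2.2-fold higher number from compound 1 to compound 4 (0.34 log units; beyond the scatter)), a modest one in which 2-(trifluoromethyl)phenyl replaces 4-chlorophenyl, whereas all three steps among the earlier compounds stayed within it. Within the data shown here, the separation holds for only one of the three pairs involving compound 4, since the steps to it from the other two compounds remain within the scatter (a 1.6-fold higher number from compound 3 to compound 4 (0.20 log units; within the scatter); a 1.4-fold higher number from compound 2 to compound 4 (0.15 log units; within the scatter)), so this position responds measurably only when the two most distant groups are compared. Nothing available here explains that step.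

The compounds shown cannot separate the trifluoromethyl group itself from its place on the phenyl ring, as no pair changes only one of these two features. They also leave open how this position would respond to a plain phenyl ring, a phenyl ring bearing an amine or a carboxylic acid, or a longer chain in place of the single saturated carbon bound to the sulfur.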